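Carbamate in Place of the Thiophene Amide Chain

The source may report more compounds than this note shows. Statements on the series, on what has been measured and on what is new or still open speak of the compounds shown alone.

Measured compounds:
compound 1 `CC(C)=CCC/C(C)=C/CC1Cc2c(O)cc(=O)n(CCCO)c2CC1(C)C` — 28.7%
compound 2 `CC(C)=CCC/C(C)=C/CC1Cc2c(OCCCNC(=O)c3cccs3)cc(=O)n(CCCO)c2CC1(C)C` — 72.8%

Of the compounds shown here, two have been measured in a functional assay on PANC-1 cells (Homo sapiens) for inhibition, read by MTT assay, with a stated time of 24 h, tested at 10 uM; on this read-out lower numbers stand for less inhibition and higher numbers for more inhibition at the one concentration tested (going by the name of the read-out). Compound 1 `CC(C)=CCC/C(C)=C/CC1Cc2c(O)cc(=O)n(CCCO)c2CC1(C)C` gives 28.7% in this assay. Going by the values given here, compound 2 `CC(C)=CCC/C(C)=C/CC1Cc2c(OCCCNC(=O)c3cccs3)cc(=O)n(CCCO)c2CC1(C)C` gives 72.8% in this assay, the highest of the two numbers; its nearest neighbour is compound 1, and the single measured step, a number 44.1 percentage points higher from compound 1 to compound 2 (beyond the scatter), lies beyond the scatter.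

Compound 3 `COc1ccccc1NC(=O)Oc1cc(=O)n(CCCO)c2c1CC(C/C=C(\C)CCC=C(C)C)C(C)(C)C2` differs from compound 2 in one place: (2-methoxyphenyl)carbamoyl in place of 3-(((thiophen-2-yl)carbonyl)amino)propyl on an oxygen on an aromatic ring. Among the compounds with values here, no measured pair shows this exchange directly. Within the data shown here, the only step that bears on it is the one from compound 1 to compound 2, which shows that putting a group of similar size on this oxygen, in place of hydrogen, raised inhibition strongly. Whether a carbamoyl group keeps that gain is not shown. The step is therefore expected to be a number 10.8 percentage points lower from compound 2 to compound 3 (beyond the scatter), within or close to the scatter, with wide uncertainty. Compound 3 is estimated at 62%, in the range 35% to 85%.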

Compound 3, a percentage reported as inhibition, at one concentration (the size of the read-out at that concentration, not a potency): 53%
Beside the measured number, compound 3's estimate is 9 percentage points above it, and the stated range covers the measured number.
By their numbers in this assay, from the lowest: compound 1; then compound 3; then compound 2.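

In this assay, the oxygen on an aromatic ring proves able to carry a second, quite different kind of group: (2-methoxyphenyl)carbamoyl in place of hydrogen gives a number 24.3 percentage points higher from compound 1 to compound 3 (beyond the scatter), so the gain is not confined to the thiophene amide chain. The group still matters beyond its size, since the two groups both hold 11 heavy atoms, yet the exchange gives a number 19.8 percentage points lower from compound 2 to compound 3 (beyond the scatter). No available evidence accounts for this difference between the two groups.

The compounds shown leave open which part of either group carries the gain, such as the methoxy group, the carbamate link or the thiophene ring. They also leave open how a plain phenylcarbamoyl group, or a propyl chain ending in an amine or a carboxylic acid, would fare on this oxygen.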